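The compounds below may be only part of what the source reports. "The series", "measured", "known", "first", "only" and "open" are said of these compounds alone.

Compound 1, `COc1ccc2oc(N3CCN(C)CC3)nc2c1`, gives 0.78 in an assay on ileum (strain Hartley) with 5-hydroxytryptamine receptor 3A (Cavia porcellus) as the target; a higher number here means a larger maximal response, a lower number a smaller maximal response.
Compound 2, `CN1CCN(c2nc3cc(F)ccc3o2)CC1`, gives 0.64 in this assay.

Going by the values given here, only one change separates these two: fluoro in place of methoxy on an aromatic carbon, and the measured step is a number 0.14 lower from compound 1 to compound 2 (beyond the scatter). Compound 2 therefore stands lowest of the two numbers, and its nearest neighbour, compound 1, sits a modest distance above it.

Compound 3, `CN1CCN(c2nc3cc(N)ccc3o2)CC1`, is the next compound in the series and has not yet been measured. Compared with compound 2 the difference is amino in place of fluoro on an aromatic carbon.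

Among the compounds with values here, no measured step swaps fluoro for amino, so the only guide is the step from methoxy to fluoro, which lowered the number modestly. Amino, like methoxy, is a small heteroatom group with hydrogen-bonding ability, whereas fluoro brings none, so a modest recovery toward the value of compound 1 seems the most reasonable expectation, with a real chance of no change beyond the scatter.

For compound 3 in this assay the estimated value is 0.73, expected to lie between 0.55 and 0.9. The expected step is a number 0.090 higher from compound 2 to compound 3 (within the scatter).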

Compound 3, intrinsic activity: the largest response reached, as a fraction of the reference agonist's: 0.76
Estimate against measurement, compound 3: 0.030 below; measured number inside the range.
By their numbers in this assay, from the lowest: compound 2; then compounds 3 and 1 (each within the scatter of the next).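

Amino in place of fluoro on this aromatic carbon gives a number 0.12 higher from compound 2 to compound 3 (beyond the scatter) in this assay, so the number at this position moves up as well as down, and the earlier drop seen with fluoro is not a fixed loss for the shared core. Amino in place of methoxy gives a number 0.020 lower from compound 1 to compound 3 (within the scatter), which means these two groups cannot be told apart in this measurement, while compound 2, with fluoro, stands lowest, its steps to both others being beyond the usual scatter. Nothing available here gives a reason for this separation, so the link between the group and the maximal response remains an observation and not an explanation.

On these data alone, three groups at a single position are too few to show a rule, and it remains open whether a hydroxyl, a methyl or a nitrile on the same aromatic carbon would sit with amino and methoxy or with fluoro. As far as these compounds go, it is also open whether amino, methoxy and fluoro would keep this same relationship on another carbon of the six-membered ring, or with a different group in place of the methyl on the piperazine.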